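Acetamido in Place of Benzoyl on the Shared Core

The compounds below may be only part of what the source reports. "The series", "measured", "known", "first", "only" and "open" are said of these compounds alone.

Compound 1 `S=C(Nc1ccc(Br)cc1)Nc1ccc2[nH]ccc2c1` gives 82% in an ADME assay on isolated protein for inhibition of peroxidase (Raphanus sativus), read by fluorescence and Amplex Red, tested at 5 uM; on this read-out higher numbers stand for a weaker effect at the one concentration tested and lower numbers for a stronger effect. Compound 2 `O=C(c1ccccc1)c1ccc(NC(=S)Nc2ccc3[nH]ccc3c2)cc1` gives 79.1% in this assay, which is the lower of the two numbers, though the step of a number 2.9 percentage points lower from compound 1 to compound 2 (within the scatter) lies within the scatter, so the two compounds cannot be set in order. Compound 3 `CC(=O)Nc1ccc(NC(=S)Nc2ccc3[nH]ccc3c2)cc1` has not yet been measured in this assay. It differs from compound 2 in one place: acetamido in place of benzoyl on an aromatic carbon. Among the measured compounds shown here, the only measured step that bears on this change is the earlier exchange at the same aromatic carbon, a number 2.9 percentage points lower from compound 1 to compound 2 (within the scatter), which stayed within the scatter. On that single precedent, no step beyond the scatter is expected in this assay for the present exchange either. The expected step is a number 0.9 percentage points higher from compound 2 to compound 3 (within the scatter), within the scatter. Compound 3 is therefore estimated at 80% in this assay, with a range from 66% to 93%.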

Compound 3, a percentage reported as activity, at one concentration (the size of the read-out at that concentration, not a potency): 68.1%
The estimate for compound 3 lay 11.9 percentage points above the measured number; the measured number falls inside the stated range.
By their numbers in this assay, from the lowest: compound 3; then compounds 2 and 1 (each within the scatter of the next).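

In this assay the exchange of benzoyl for acetamido on this aromatic carbon gives a number 11 percentage points lower from compound 2 to compound 3 (beyond the scatter) while the exchange of bromo for acetamido gives a number 13.9 percentage points lower from compound 1 to compound 3 (beyond the scatter) so this position can move the read-out beyond the scatter, which the step between the two earlier compounds did not show. Acetamido brings one hydrogen-bond donor and no ring where benzoyl brings no donor and a six-membered aromatic ring, yet these compounds do not separate the two differences. Nothing measured here explains the result.

On these data alone, whether the amide hydrogen or the loss of the ring matters remains open. A free amine, a carboxylic acid or a longer acyl chain on the same carbon would be needed to tell how far the trend extends beyond acetamido.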